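The compounds below may be only part of what the source reports. "The series", "measured", "known", "first", "only" and "open" are said of these compounds alone.

In a functional assay on cells (Platelet, Homo sapiens) for inhibition (a lower number here means a stronger inhibitor, a higher number a weaker inhibitor), compound 1 `CCOC(=O)c1ccc(-c2nn(C)c3ccccc23)cc1` gives 270 nM and compound 2 `CCOC(=O)c1ccc(-c2nn(Cc3ccccc3F)c3ccccc23)cc1` gives 110 nM. Among the measured compounds shown here, the change between them is a 2.5-fold lower number from compound 1 to compound 2 (0.39 log units; beyond the scatter), and it is the only measured step. Compound 3 `CC(C)OC(=O)c1ccc(-c2nn(Cc3ccccc3)c3ccccc23)cc1` reads > 10000 nM in this assay, which is a limit of the assay and not a number. The ceiling is thus already reached once: the limit of > 10000 nM in this assay, at which 1 of the 3 values shown sits. For the measured compounds named here, no step can be counted from compound 3, and its place on the scale is known only as that limit.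

Compound 4 `CC(C)NC(=O)c1ccc(-c2nn(Cc3ccccc3)c3ccccc23)cc1` differs at one place: isopropylamino in place of isopropoxy on a carbonyl carbon. Here isopropylamino stands in place of isopropoxy on a carbonyl carbon, which reads as isopropoxycarbonyl to isopropylcarbamoyl. Going by the values given here, the one measured step lies elsewhere, on a saturated chain carbon bound to an aromatic nitrogen. Among the compounds with values here, it is modest and does not bear directly on this replacement, and no measured pair covers the carbonyl change. The only anchor is therefore the limit of compound 3, > 10000 nM. No clear step in either direction is expected, and a second reading at the limit is quite possible. The estimated step is a number no higher from compound 3 to compound 4 (the limit leaves the size open). For compound 4 the expected value is 10000 nM, with an estimated range of 3000 nM to 30000 nM.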

Compound 4, half-maximal inhibitory concentration: > 10000 nM
Compound 4: no number, only a limit; the forecaster's own chance of this, stated with the estimate: 60%; the middle value lies on the limit itself.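

In this assay compound 4 reads > 10000 nM, a limit and not a number, and compound 3 also stands only as a limit, so no step can be read between them. The ceiling is now reached twice: the limit of > 10000 nM in this assay, at which 2 of the 4 values shown sit. The compounds shown leave open how isopropylamino and isopropoxy on the carbonyl carbon compare in this read-out.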